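The source may hold more compounds than are shown below. What is called first, only, known or untested is meant among the compounds shown, and "the series" means these compounds.

Of the compounds shown here, three that share a core have been measured in an assay on NIH3T3 cells with Urotensin-2 receptor (Homo sapiens) as the target; a higher number here means a larger maximal response, a lower number a smaller maximal response. Compound 1, `CCc1ccccc1C(=O)OC(CCN(C)C)c1ccc(Cl)cc1`, gives 128% in this assay. Compound 2, `Cc1ccc(C(=O)OC(CCN(C)C)c2ccc(Cl)cc2)cc1`, gives 56%. Compound 3, `COc1ccc(NC(=O)OC(CCN(C)C)c2ccc(Cl)cc2)cc1`, gives 170%, the highest of the three numbers, with its steps to compound 1 and to compound 2 both beyond the scatter. Among the measured compounds shown here, the one step between measured compounds that differ in a single place is a number 72 percentage points lower from compound 1 to compound 2 (beyond the scatter), a large change for swapping one aromatic group for another on a carbonyl carbon.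

Compound 4, `CN(C)CCC(OC(=O)NCc1ccccc1)c1ccc(Cl)cc1`, has not yet been measured. It differs from compound 3 in this way: benzyl in place of 4-methoxyphenyl on an amide-type nitrogen. For the measured compounds named here, no measured step changes a group on the amide-type nitrogen, so nothing bears directly on this change; the step from compound 1 to compound 2 only shows that exchanging one aromatic group for another can move the result by a large amount. Because compound 3 already stands highest at 170%, the expected step for compound 4 is a number 50 percentage points lower from compound 3 to compound 4 (beyond the scatter). The expected value for compound 4 is 120%, with a range from 60% to 180%.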

Compound 4, largest response reached (reported as efficacy), in percent of the reference or control that the assay uses: 180%
Compound 4: the middle estimate sits 60 percentage points below what was measured; measured number inside the range.
By their numbers in this assay, from the lowest: compound 2; then compound 1; then compounds 3 and 4 (each within the scatter of the next).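

On the amide-type nitrogen, benzyl in place of 4-methoxyphenyl gives a number 10 percentage points higher from compound 3 to compound 4 (within the scatter) in this assay, so this exchange of one aromatic group for another, unlike the one on the carbonyl carbon, leaves compound 3 and compound 4 indistinguishable. Benzylamino on the carbonyl carbon gives a number 124 percentage points higher from compound 2 to compound 4 (beyond the scatter) when it replaces 4-methylphenyl and a number 52 percentage points higher from compound 1 to compound 4 (beyond the scatter) when it replaces 2-ethylphenyl, so compound 4 stands clearly above both compounds that carry an aromatic group directly on that carbon. Nothing measured here offers an explanation for these results.

From the compounds shown here alone, whether the aromatic ring on this nitrogen matters at all remains open, since a plain butyl chain there would test that. Going by these compounds, it is also open how far the ring can move away, as a phenylethyl group would show, or whether a carboxylic acid on the ring would be tolerated.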